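Swapping the phenyl of compound 2 for a pyrazolyl ring

A few compounds are considered here, and "the series" means these few. Any claim that something is new, unique, unknown or untested is made for them only; others in the source may bear on it.

In an assay on HEK293 cells for agonist activity at Toll-like receptor 8 (Homo sapiens), read by spectrophotometry (a higher number here means that more compound is needed for the effect, a lower number that less compound is needed), compound 2 `CCCCNc1nc(N)nc(C)c1CCCc1ccccc1` gives 749 nM, the highest of the two numbers measured. Among the compounds with values here, its only neighbour, compound 1 `CCCCNc1nc(N)nc(C)c1CCCN1CCCCC1`, gives 133 nM in this assay, and the single step between them, a 5.6-fold higher number from compound 1 to compound 2 (0.75 log units; beyond the scatter), is the one measured change at this chain position. Compound 3 `CCCCNc1nc(N)nc(C)c1CCCn1cccn1` continues from compound 2 by 1H-pyrazol-1-yl in place of phenyl on a saturated chain carbon, three bonds along the chain from an aromatic carbon; the same difference, cut one bond further out, reads benzyl to (1H-pyrazol-1-yl)methyl. The ring that enters is aromatic like the phenyl it replaces, yet brings two hydrogen-bond acceptors where the phenyl had none, so it sits between the two rings already tested. Because the step of a 5.6-fold higher number from compound 1 to compound 2 (0.75 log units; beyond the scatter) was modest, and the new ring shares features of both, only a small move toward a lower number, or none beyond the scatter, is expected. The estimate for compound 3 in this assay is 500 nM, with a range from 150 nM to 1500 nM, a step of a 1.5-fold lower number from compound 2 to compound 3 (0.18 log units; within the scatter).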

Compound 3, half-maximal effective concentration: 1050 nM
Beside the measured number, compound 3's estimate is 2.1-fold (0.32 log units) below it; the measured number falls inside the stated range.
By their numbers in this assay, from the lowest: compound 1; then compounds 2 and 3 (each within the scatter of the next).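

In this assay, replacing phenyl with 1H-pyrazol-1-yl on this chain carbon gives a 1.4-fold higher number from compound 2 to compound 3 (0.15 log units; within the scatter), so the hydrogen-bond acceptors counted for the entering ring bring no change beyond the scatter. Set against piperidin-1-yl, the same ring gives a 7.9-fold higher number from compound 1 to compound 3 (0.90 log units; beyond the scatter), which shows that the gap first seen with phenyl also holds for a second aromatic ring, with compound 1 alone at the lower number among the three compounds. No measurement is available that explains this result.

The compounds shown leave open whether the lower number of compound 1 goes with the nitrogen of piperidin-1-yl or with a non-aromatic ring in general. A cyclohexyl group or a diethylamino group on the same chain carbon would separate these two readings.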